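This account rests on a few compounds, and the source may have more. Where it says the series, first, only, none or still open, it means among the compounds named here.

Among the measured compounds shown here, compound 1 `COc1cc(Cl)cc(-c2nn(-c3cccc(NC(=O)c4ccc(Cl)c(Cl)c4)c3)cc2-c2ccncc2)c1` sits at the top of the three numbers measured so far in a functional assay on SK-MEL-2 cells (Homo sapiens) for inhibition, read by sulforhodamine B assay, with a stated time of 48 h, tested at 10 uM (a higher number here means a weaker effect of the compound at the concentration tested, a lower number a stronger effect), where compound 1 gives 78.4%. The two other measured compounds both carry a urea rather than an amide at the same position on the shared core: compound 2 `O=C(Nc1cccc(-n2cc(-c3ccncc3)c(-c3cc(O)cc(Cl)c3)n2)c1)Nc1ccc(Cl)c(C(F)(F)F)c1` gives -38% in this assay, and compound 3 `COc1cc(Cl)cc(-c2nn(-c3cccc(NC(=O)Nc4cc(C(F)(F)F)cc(C(F)(F)F)c4)c3)cc2-c2ccncc2)c1` gives -38.1% there. Both of those numbers lie far below that of compound 1, well beyond the usual scatter, so the amide of compound 1 stands alone as the weak member of the set.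

Compound 4 `COc1cc(Cl)cc(-c2nn(-c3cccc(NC(=O)Nc4ccc(Cl)c(Cl)c4)c3)cc2-c2ccncc2)c1` has not yet been measured in this assay. It differs from compound 1 in one place: (3,4-dichlorophenyl)amino in place of 3,4-dichlorophenyl on a carbonyl carbon. The new compound thus joins compounds 2 and 3 as a urea, while keeping the methoxy-bearing ring of compounds 1 and 3 and the 3,4-dichlorophenyl of compound 1.

Since both ureas measured so far, compound 2 with -38% and compound 3 with -38.1%, lie deep in the strongly active range, compound 4 is expected to follow them, with a step from compound 1 of a number 103.4 percentage points lower from compound 1 to compound 4 (beyond the scatter) expected. For compound 4 the estimate in this assay is -25%, with a range from -55% to 25%.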

Compound 4, a percentage reported as activity, at one concentration (the size of the read-out at that concentration, not a potency): -32.1%
The estimate for compound 4 lay 7.1 percentage points above the measured number; the range from low to high includes it.
By their numbers in this assay, from the lowest: compounds 3, 2 and 4 (each within the scatter of the next); then compound 1.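

In this assay, among the compounds shown here, the single change on the carbonyl carbon, (3,4-dichlorophenyl)amino in place of 3,4-dichlorophenyl, gives a large step, a number 110.5 percentage points lower from compound 1 to compound 4 (beyond the scatter), with everything else in the molecule held constant. The earlier compounds shown here could not show this, as compounds 2 and 3 differ from compound 1 in more than one place, so their low numbers could not be assigned to the urea alone; this pair, which keeps the 3,4-dichlorophenyl and the methoxy-bearing ring, ties the step directly to the change from amide to urea at this position. No supporting measurement is available to explain why this one change has so large an effect.

Going by these compounds, it remains open whether the step depends on the added nitrogen and the hydrogen it carries, a question that a methylene group, an ether oxygen as in a carbamate, or a methyl-substituted urea nitrogen at the same place could address. On these data alone, it is also open whether the step would persist if the 3,4-dichlorophenyl on the urea gave way to a saturated ring such as cyclohexyl.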